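This account rests on a few compounds, and the source may have more. Where it says the series, first, only, none or still open, it means among the compounds named here.

Measured so far:
- compound 1 `COc1cc(-c2nn(-c3cccc(NC(=O)Nc4cc(C(F)(F)F)cc(C(F)(F)F)c4)c3)cc2-c2ccncc2)ccc1Cl` — 1150 nM
- compound 2 `COc1cc(-c2nn(-c3cccc(NC(=O)Nc4cccc(C(F)(F)F)c4)c3)cc2-c2ccncc2)ccc1Cl` — 1770 nM

Among the measured compounds shown here, in a functional assay on HOP-92 cells (Homo sapiens) for inhibition, read by sulforhodamine B assay, with a stated time of 48 h (on this read-out lower numbers stand for stronger inhibition of growth and higher numbers for weaker inhibition of growth), compound 2 gives 1770 nM, and its only neighbour, compound 1, lies within the scatter of that value. Compound 3 `COc1cc(-c2nn(-c3cccc(NC(=O)c4ccccc4)c3)cc2-c2ccncc2)ccc1Cl` carries the change (phenyl in place of (3-(trifluoromethyl)phenyl)amino on a carbonyl carbon). For the measured compounds named here, the one measured step, a 1.5-fold higher number from compound 1 to compound 2 (0.19 log units; within the scatter), concerns only a trifluoromethyl on the aromatic ring and stayed within the scatter; no measured step removes the amide-type nitrogen itself, so this change is untested here. Somewhat weaker inhibition is expected, a step of a 2.0-fold higher number from compound 2 to compound 3 (0.30 log units; within the scatter), giving for compound 3 an estimate of 3500 nM in a range from 1200 nM to 12000 nM.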

Compound 3, concentration for total growth inhibition: 4710 nM
The estimate for compound 3 lay 1.3-fold (0.13 log units) below the measured number, and the stated range covers the measured number.
By their numbers in this assay, from the lowest: compounds 1 and 2 (each within the scatter of the next); then compound 3.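

Unlike the trifluoromethyl step, which stayed within the scatter, this change on the carbonyl carbon moves the result beyond it: in this assay the change gives a 2.7-fold higher number from compound 2 to compound 3 (0.43 log units; beyond the scatter) and so modestly weaker inhibition of growth. The swap removes the amino nitrogen and the trifluoromethyl together, so their shares in the step cannot be separated. Nothing available explains the shift.

Going by these compounds, it remains open how a benzyl group or a simple methyl on that carbonyl carbon would compare, and whether a phenyl bearing trifluoromethyl would restore the earlier level.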